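Changing the Aryl Substituent in a Vinyl Sulfone Series

The source may hold more compounds than are shown below. What is called first, only, known or untested is meant among the compounds shown, and "the series" means these compounds.

Measured compounds:
compound 1 `CC(=O)Oc1ccc(/C=C(\C(=O)c2ccc(Cl)cc2)S(=O)(=O)c2ccc(C)cc2)cc1` 25000 nM
compound 2 `CSc1ccc(/C=C(/SCc2ccc(Cl)cc2)C(=O)c2ccc(Cl)cc2)cc1` 25000 nM
compound 3 `Cc1ccc(S(=O)(=O)/C(=C/c2ccc(Oc3ccccc3)cc2)C(=O)c2ccc(Cl)cc2)cc1` 1000 nM

In a functional assay on DU-145 cells (Homo sapiens) for inhibition, read by trypan blue exclusion, with a stated time of 96 h (on this read-out higher numbers stand for weaker inhibition of growth and lower numbers for stronger inhibition of growth), compound 1 gives 25000 nM, the same number as compound 2 and the highest of the three. For the measured compounds named here, the one step measured from it, a 25-fold lower number from compound 1 to compound 3 (1.40 log units; beyond the scatter), shows that a change at the oxygen on this aromatic ring can move the read-out strongly. Compound 4 `COc1ccc(/C=C(\C(=O)c2ccc(Cl)cc2)S(=O)(=O)c2ccc(C)cc2)cc1O` alters the same ring differently: 3-hydroxy-4-methoxyphenyl in place of 4-acetoxyphenyl on a double-bonded chain carbon bound to a double-bonded chain carbon. Going by the values given here, no measured pair isolates this exact exchange, so the direction is uncertain; a moderate drop in number is expected, smaller than a 25-fold lower number from compound 1 to compound 3 (1.40 log units; beyond the scatter). Compound 4 is estimated at 8000 nM (range 1500 nM to 25000 nM), which means an expected step of a 3.1-fold lower number from compound 1 to compound 4 (0.49 log units; beyond the scatter).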

Compound 4, concentration for 50% growth inhibition: 1000 nM
Compound 4: middle estimate off by 8.0-fold (0.90 log units), on the high side; the measured number lies below the stated range.
By their numbers in this assay, from the lowest: compounds 3 and 4 (each within the scatter of the next); then compounds 1 and 2 (each within the scatter of the next).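

In this assay, the step of a 25-fold lower number from compound 1 to compound 4 (1.40 log units; beyond the scatter) shows that a large gain does not depend on the phenyl group of compound 3, since a different exchange on the same ring does as much. Compound 3 and compound 4 print the same number, so two unlike groups reach one level here. Nothing given here accounts for this drop.

As far as these compounds go, the exchange changes two things at once, so the share of the hydroxy group and that of the methoxy group remain unknown. From the compounds shown here alone, it also remains open whether an amine or a carboxylic acid on this ring would do the same.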